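Cytotoxicity Estimate for a Bromophenyl Ether Analogue

A few compounds are considered here, and "the series" means these few. Any claim that something is new, unique, unknown or untested is made for them only; others in the source may bear on it.

Measured compounds:
compound 1, `CCC1(Cc2ccccc2)OS(=O)(=O)C=C1OCc1ccc(Cl)c(Cl)c1`, gives 36700 nM in an ADME assay on HEL cells (Homo sapiens) for cytotoxicity, with a stated time of 3 days; on this read-out lower numbers stand for higher toxicity in this test and higher numbers for lower toxicity in this test
compound 2, `CCC1(Cc2ccccc2)OS(=O)(=O)C=C1OCc1ccccc1Cl`, gives 38000 nM
compound 3, `CCC1(Cc2ccccc2)OS(=O)(=O)C=C1OCCCCCCc1ccccc1`, gives only a limit, < 200000 nM

Compound 1 carries one of the two plain numbers in this assay; the other, for compound 2, lies within the scatter of it, as the step of a 1.0-fold higher number from compound 1 to compound 2 (0.02 log units; within the scatter) shows. Compound 4, `CCC1(Cc2ccccc2)OS(=O)(=O)C=C1OCc1ccc(Br)cc1`, differs from compound 1 in this way: 4-bromophenyl in place of 3,4-dichlorophenyl on a saturated chain carbon bound to an oxygen on an unsaturated carbon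

Going by the values given here, the only measured step that bears on this change is a 1.0-fold higher number from compound 1 to compound 2 (0.02 log units; within the scatter), where another halogenated phenyl replaced the same group at the same place and the number did not move beyond the scatter. The limit for compound 3, (the limit of < 200000 nM in this assay, at which 1 of the 3 values shown sits), gives no number to weigh. An exchange of one halogenated phenyl for another is therefore expected to leave the reading essentially unchanged, a 1.1-fold higher number from compound 1 to compound 4 (0.04 log units; within the scatter). Compound 4 is estimated at 40000 nM in this assay, with a range of 15000 nM to 110000 nM.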

Compound 4, half-maximal cytotoxic concentration: 171000 nM
Compound 4: the middle estimate sits 4.3-fold (0.63 log units) below what was measured; the measured number lies above the stated range.
By their numbers in this assay, from the lowest: compounds 1 and 2 (each within the scatter of the next); then compound 4.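

At this position in this assay, one halogenated phenyl cannot simply stand in for another: 4-bromophenyl in place of 3,4-dichlorophenyl gives (a 4.7-fold higher number from compound 1 to compound 4 (0.67 log units; beyond the scatter)), and 4-bromophenyl in place of 2-chlorophenyl gives (a 4.5-fold higher number from compound 2 to compound 4 (0.65 log units; beyond the scatter)). Compounds 1 and 2 thus read alike despite their different chlorine patterns, while compound 4 shows lower toxicity in this test than either. Nothing measured here explains this difference. The compounds shown leave open whether the change follows from bromine itself or from its place on the ring. A 4-chlorophenyl or an unsubstituted phenyl group at this position would help separate the two.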